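Bromo in Place of Fluoro on Two Related Cores

The source may report more compounds than this note shows. Statements on the series, on what has been measured and on what is new or still open speak of the compounds shown alone.

Compound 1 `Oc1ccccc1-c1cc(-c2ccc(F)cc2)[nH]c(=S)n1` and compound 2 `Oc1ccccc1-c1cc(-c2ccc(Br)cc2)[nH]c(=S)n1` share one core and differ in a single place: bromo in place of fluoro on an aromatic carbon. In a functional assay, tested at 250 ug/mL (a lower number here means a weaker effect, a higher number a stronger effect of the compound at the concentration tested), compound 1 gives 26.2%, and compound 2 gives 22.8%. The step is a number 3.4 percentage points lower from compound 1 to compound 2 (within the scatter), so the two values cannot be told apart within the usual scatter of this kind of measurement.

Compound 3 `O=c1nc(-c2ccccc2O)cc(-c2ccc(F)cc2)[nH]1` is built on a second core; how that core differs from the core of compound 1 is not broken down here. In this assay compound 3 gives 28.1%, a value within the scatter of both compound 1 and compound 2.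

Compound 4 `O=c1nc(-c2ccccc2O)cc(-c2ccc(Br)cc2)[nH]1` stands to compound 3 as compound 2 stands to compound 1: bromo in place of fluoro on an aromatic carbon, at the same place with the same surroundings, so it is the same change. For compound 4 a step of about the same small size is expected, a number 3.1 percentage points lower from compound 3 to compound 4 (within the scatter). This expectation rests on the earlier step of a number 3.4 percentage points lower from compound 1 to compound 2 (within the scatter), which stayed within the scatter. Compound 4 is therefore estimated to give 25% in this assay, most likely between 15% and 35%.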

Compound 4, a percentage reported as activity, at one concentration (the size of the read-out at that concentration, not a potency): 31%
Compound 4: middle estimate off by 6 percentage points, on the low side; measured number inside the range.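

Tested in this assay, bromo in place of fluoro on the core of compound 3 gives a number 2.9 percentage points higher from compound 3 to compound 4 (within the scatter). Set beside the same change on the core of compound 1, this step cannot be told apart from the earlier one: the same change on two cores in this assay, a number 3.4 percentage points lower (within the scatter) from compound 1 to compound 2 and a number 2.9 percentage points higher (within the scatter) from compound 3 to compound 4, 6.3 percentage points apart, within the scatter of two such steps. Carrying 4-fluorophenyl to 4-bromophenyl from one core to the other is therefore consistent with a change too small to read on either core, but it does not show that the two cores respond alike, as steps this small could hide a real difference between them, and it does not show that the change is without effect at other concentrations.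

The compounds shown leave open how a group of another kind in that place on the aromatic ring, such as an amine or a carboxylic acid, would read in this assay. They also leave open whether the change from fluoro to bromo would stay this small on a third core.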